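The compounds below may be only part of what the source reports. "The series", "measured", "known", "first", "only" and "open" are said of these compounds alone.

Compound 1 `CC1(/C=C/c2ccccc2)C=CC(=O)O1` has no exact position on this scale. In a functional assay on K562 cells (Homo sapiens) for inhibition, read by sulforhodamine B assay, with a stated time of 48 h (on this read-out higher numbers stand for weaker inhibition of growth and lower numbers for stronger inhibition of growth), compound 1 gives > 1000000 nM, which is a limit of the assay and not a number. Compound 4 `COc1cccc(/C=C/C2(C)C=CC(=O)O2)c1` differs from compound 1 by methoxy in place of hydrogen on an aromatic carbon.

Among the compounds with values here, two measured steps bear on this change, since each also replaces hydrogen on an aromatic carbon. Within the data shown here, compound 2 `CC1(/C=C/c2ccccc2C(F)(F)F)C=CC(=O)O1` carries trifluoromethyl there and gives 573000 nM, the only true number so far. That substitution yields an at least 1.7-fold lower number from compound 1 to compound 2 (0.24 log units; that floor lies within the scatter). Compound 3 `CC1(/C=C/c2ccc(O)cc2)C=CC(=O)O1` carries hydroxy instead. In this assay compound 3 gives > 1000000 nM, which is also a limit. That substitution yields a step that the two limits leave unreadable from compound 1 to compound 3. Neither step fixes a firm size because the limit of > 1000000 nM in this assay, at which 2 of the 3 values shown sit, hides the true starting point.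

With only the small floor of an at least 1.7-fold lower number from compound 1 to compound 2 (0.24 log units; that floor lies within the scatter) as a guide, no large step is expected for methoxy. Any expected shift would run towards a slightly lower number, and it may not rise beyond the scatter. Compound 4 could well remain at the limit too. The expected step is an at least 1.1-fold lower number from compound 1 to compound 4 (0.04 log units; that floor lies within the scatter). In this assay the estimate for compound 4 is 900000 nM, with an expected range from 450000 nM to 1500000 nM.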

Compound 4, concentration for total growth inhibition: > 1000000 nM
Compound 4 was reported as a limit; the forecaster's own chance of this, stated with the estimate: 55%; at least 1.1-fold (0.04 log units) between middle value and limit.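

In this assay compound 4 gives > 1000000 nM, which is a limit of the assay and not a number. Within the data shown here, no step from compound 1 to compound 4 can be read, because both compounds stand at the same limit: the limit of > 1000000 nM in this assay, at which 3 of the 4 values shown sit. The compounds shown leave open where compound 1, compound 3 and compound 4 truly lie on this scale, and whether methoxy in place of hydrogen on an aromatic carbon changes the read-out at all.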